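The compounds below may be only part of what the source reports. "The series", "measured", "known", "first", "only" and "open" are said of these compounds alone.

Notes on the series. Compound 1 `NNc1nonc1/C(=N/O)Nc1ccc(F)c(Br)c1` gives 108 nM in an assay on isolated protein for inhibition of Indoleamine 2,3-dioxygenase 1 (Homo sapiens), read by fluorescence, with a stated time of 60 min; on this read-out higher numbers stand for weaker inhibition and lower numbers for stronger inhibition. Compound 2 `NS(=O)(=O)NNc1nonc1/C(=N/O)Nc1ccc(F)c(Br)c1` gives 218 nM; the step of a 2.0-fold higher number from compound 1 to compound 2 (0.31 log units; beyond the scatter) is modest but beyond the scatter. Compound 3 `CN(C)S(=O)(=O)CCNc1nonc1/C(=N/O)Nc1ccc(F)c(Br)c1` gives 105 nM. From compound 1 the step of a 1.0-fold lower number from compound 1 to compound 3 (0.01 log units; within the scatter) lies within the scatter, so compound 3 and compound 1 sit together; against compound 2 the step of a 2.1-fold lower number from compound 2 to compound 3 (0.32 log units; beyond the scatter) is modest and beyond the scatter, so compound 3 stands apart from compound 2 but not from compound 1.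

Compound 4 `CCNS(=O)(=O)CCNc1nonc1/C(=N/O)Nc1ccc(F)c(Br)c1` differs from compound 3 by ethylamino in place of dimethylamino on a sulfonyl sulfur. Among the measured compounds shown here, no measured step alters this part of the molecule: the steps to compound 3 exchange the whole substituent on the ring nitrogen, and the only step touching a sulfonyl group, from compound 1 to compound 2, sits on a different nitrogen. For the measured compounds named here, nothing among the measured compounds indicates that this rearrangement at the sulfonyl sulfur would move the number, so the step is expected to be a 1.0-fold higher number from compound 3 to compound 4 (0.02 log units; within the scatter), within the scatter. For compound 4 the expected value is 110 nM, with a range from 55 nM to 220 nM.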

Compound 4, half-maximal inhibitory concentration: 95 nM
Estimate against measurement, compound 4: 1.2-fold (0.06 log units) above; the measured number falls inside the stated range.
By their numbers in this assay, from the lowest: compounds 4, 3 and 1 (each within the scatter of the next); then compound 2.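

The sulfonyl sulfur now has a measured step of its own: ethylamino in place of dimethylamino brings a hydrogen-bond donor, yet the result is a 1.1-fold lower number from compound 3 to compound 4 (0.04 log units; within the scatter), so this exchange leaves the number unmoved in this assay. The wider exchanges on the nitrogen on an aromatic ring read as they did for 2-(dimethylsulfamoyl)ethyl: 2-(ethylsulfamoyl)ethyl in place of amino gives a 1.1-fold lower number from compound 1 to compound 4 (0.06 log units; within the scatter), while in place of sulfamoylamino it gives a 2.3-fold lower number from compound 2 to compound 4 (0.36 log units; beyond the scatter), leaving only compound 2 apart from the others. Nothing measured accounts for this flat response at the sulfur.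

Still open, as far as these compounds go, is whether a piperidine on the sulfonyl sulfur, or a carboxylic acid in place of the sulfamoyl group, would hold this level. A chain longer than 2-(ethylsulfamoyl)ethyl on that nitrogen is equally untested by the compounds shown.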